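The source may report more compounds than this note shows. Statements on the series, on what has been measured and on what is new or still open speak of the compounds shown alone.

Cytotoxicity notes on the series in an ADME assay on Vero cells (Chlorocebus sabaeus) for cytotoxicity, read by MTT assay, with a stated time of 72 h; a lower number here means that less compound is tolerated, a higher number that more compound is tolerated. Compound 1 `O=C(/C=C/c1cccc(Cl)c1)Nc1nnc(-c2ccccc2)[nH]1` gives 1470000 nM; compound 2 `O=C(/C=C/c1ccc([N+](=O)[O-])s1)Nc1nnc(-c2ccccc2)[nH]1` gives 1670000 nM; compound 3 `C=C(C)COc1ccc(/C=C/C(=O)Nc2nnc(-c3ccccc3)[nH]2)cc1` gives 1420000 nM. Compound 1 holds the second highest of the three numbers, within the scatter of both neighbours: compound 3 lies nearest, compound 2 furthest, and neither gap goes beyond the scatter. Going by the values given here, the only single-point step measured so far, a 1.1-fold higher number from compound 1 to compound 2 (0.06 log units; within the scatter), swaps the whole aryl on the chain for a different one and moves nothing beyond the scatter.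

Compound 4 `Cc1ccc(/C=C/C(=O)Nc2nnc(-c3ccccc3)[nH]2)cc1` differs from compound 1 by 4-methylphenyl in place of 3-chlorophenyl on a double-bonded chain carbon bound to a double-bonded chain carbon. That change sits at the same place as the step from compound 1 to compound 2, and since that step stayed within the scatter, no step beyond the scatter in this assay is expected here either, in no particular direction. Compound 4 is therefore expected to give about 1500000 nM, with a range from 900000 nM to 2500000 nM, that is an expected step of a 1.0-fold higher number from compound 1 to compound 4 (0.01 log units; within the scatter).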

Compound 4, half-maximal cytotoxic concentration: 1760000 nM
Compound 4: the middle estimate sits 1.2-fold (0.07 log units) below what was measured; the range from low to high includes it.
By their numbers in this assay, from the lowest: compounds 3, 1, 2 and 4 (each within the scatter of the next).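

In this assay the swap of 4-methylphenyl in place of 3-chlorophenyl on a double-bonded chain carbon bound to a double-bonded chain carbon gives a 1.2-fold higher number from compound 1 to compound 4 (0.08 log units; within the scatter) and stays within the scatter, so a second aryl change at this position, this time with chlorine leaving and an all-carbon group entering, moves nothing beyond it. Compound 4 also stands within the scatter of the other two compounds: a 1.2-fold higher number from compound 3 to compound 4 (0.09 log units; within the scatter) with methyl in place of (2-methylprop-2-en-1-yl)oxy on an aromatic carbon, and a 1.1-fold higher number from compound 2 to compound 4 (0.02 log units; within the scatter) with 4-methylphenyl in place of 5-nitrothiophen-2-yl at the chain carbon. Nothing measured here speaks to why these numbers stay together.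

Going by these compounds, whether an aryl group carrying an amine or a carboxylic acid at this place would stay within the scatter remains open. So does the effect of a longer chain in place of methyl on the aromatic carbon.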